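From a hexyl chain to a thiophene-bearing branch

The source may hold more compounds than are shown below. What is called first, only, known or untested is meant among the compounds shown, and "the series" means these compounds.

Three measured compounds share one core and differ only in the group on the amide-type nitrogen. Compound 1 `Cc1nc(N)sc1CCCN/C(N)=N/C(=O)NC(C)c1ccc(Br)cc1` carries a branched group with a ring, compound 2 `Cc1nc(N)sc1CCCN/C(N)=N/C(=O)NCc1ccco1` carries a furan-2-yl group on a saturated chain carbon, and compound 3 `CCCCCCNC(=O)/N=C(\N)NCCCc1sc(N)nc1C` carries a plain hexyl chain. In a functional assay on Right cardiac atrium for agonist activity at histamine H2 receptor (Cavia porcellus), with a stated time of 30 min, in the presence of a further agent that is not named here (on this read-out lower numbers stand for smaller maximal responses and higher numbers for larger maximal responses), compound 1 gives 0.87, compound 2 gives 0.58, and compound 3 gives 0.95. Compound 3 stands beyond the scatter from compound 2, while its gap to compound 1 lies within the scatter. Within the data shown here, the only step between measured neighbours, a number 0.37 higher from compound 2 to compound 3 (beyond the scatter), shows how much the chain gained over the ring-bearing group.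

Compound 4 `Cc1nc(N)sc1CCCN/C(N)=N/C(=O)NC(C)c1cccs1` is the next step: 1-(thiophen-2-yl)ethyl in place of hexyl on an amide-type nitrogen. This runs the measured step in reverse, putting a five-membered aromatic ring back in place of the chain, yet compound 1, also ring-bearing and branched, stayed close to compound 3. A fall is therefore expected, but a smaller one than the measured step, estimated as a number 0.17 lower from compound 3 to compound 4 (beyond the scatter). Compound 4 is expected to give 0.78, within a range from 0.6 to 0.95.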

Compound 4, intrinsic activity: the largest response reached, as a fraction of the reference agonist's: 0.88
Compound 4: the middle estimate sits 0.10 below what was measured; low and high end bracket the measured number.
By their numbers in this assay, from the lowest: compound 2; then compounds 1, 4 and 3 (each within the scatter of the next).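

A ring on this amide-type nitrogen need not cost any maximal response: exchanging hexyl for 1-(thiophen-2-yl)ethyl gives a number 0.070 lower from compound 3 to compound 4 (within the scatter), and exchanging 4-bromophenyl for thiophen-2-yl on the saturated chain carbon gives a number 0.010 higher from compound 1 to compound 4 (within the scatter). A five-membered aromatic ring alone therefore does not account for the low response of the (furan-2-yl)methyl group, for 1-(thiophen-2-yl)ethyl in its place gives a number 0.30 higher from compound 2 to compound 4 (beyond the scatter). Nothing available here explains these results.

Going by these compounds, that last change alters the ring and the chain carbon's substitution together, so it remains open whether (thiophen-2-yl)methyl or 1-(furan-2-yl)ethyl would behave like compound 2 or like compound 4. Also open, on these data alone, is how the response would change with an amine or a carboxylic acid at the end of the hexyl chain.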